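Dihydropyridine Aryloxyacetamides: Anti-Inflammatory Read-Out, Step to Pyrazolyl Amide

This account rests on a few compounds, and the source may have more. Where it says the series, first, only, none or still open, it means among the compounds named here.

Measured compounds:
- compound 1, `CCOC(=O)C1=C(C)NC(C)=C(C(=O)OCC)C1c1ccc(OCC(=O)NCc2ccccc2)cc1`: 16.1%
- compound 2, `CCOC(=O)C1=C(C)NC(C)=C(C(=O)OCC)C1c1ccc(OCC(=O)NNC(=O)c2ccc(C)cc2)cc1`: 35.9%
- compound 3, `CCOC(=O)C1=C(C)NC(C)=C(C(=O)OCC)C1c1ccc(OCC(=O)NNC(=O)c2sccc2Cl)cc1`: 39.7%

In a functional assay on the whole organism (strain Wistar) for inhibition, with Rattus norvegicus as the target, read by paw edema, with stated times of 30 min and 1 h, at a dose of 20 mg/kg (on this read-out lower numbers stand for less inhibition and higher numbers for more inhibition at the one dose given (going by the name of the read-out)), compound 2 stands second highest of the three numbers. Its nearest neighbour is compound 3, a step of a number 3.8 percentage points higher from compound 2 to compound 3 (within the scatter), within the scatter; its furthest is compound 1, from which compound 2 is reached by a number 19.8 percentage points higher from compound 1 to compound 2 (beyond the scatter), beyond the scatter.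

Compound 4, `CCOC(=O)C1=C(C)NC(C)=C(C(=O)OCC)C1c1ccc(OCC(=O)n2nc(C)cc2C)cc1`, is not yet measured. Its change from compound 2 is 3,5-dimethyl-1H-pyrazol-1-yl in place of (((4-methylphenyl)carbonyl)amino)amino on a carbonyl carbon.

Going by the values given here, no measured step alters this position in the same way. The steps of a number 19.8 percentage points higher from compound 1 to compound 2 (beyond the scatter) and a number 23.6 percentage points higher from compound 1 to compound 3 (beyond the scatter) show that replacing benzyl by an acylamino group on the amide-type nitrogen raised inhibition modestly; the step of a number 3.8 percentage points higher from compound 2 to compound 3 (within the scatter) shows that exchanging the group on the carbonyl carbon stayed within the scatter. Compound 4 removes the acylamino arrangement altogether, so a modest fall toward the level of compound 1 is expected, but with wide uncertainty.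

For compound 4 in this assay the expected value is 25%, range 10% to 42%, an expected step of a number 10.9 percentage points lower from compound 2 to compound 4 (beyond the scatter).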

Compound 4, a percentage reported as inhibition, in the whole organism at one dose (the size of the read-out at that dose, not a potency): 32.7%
The estimate for compound 4 lay 7.7 percentage points below the measured number; the measured number falls inside the stated range.
By their numbers in this assay, from the lowest: compound 1; then compounds 4, 2 and 3 (each within the scatter of the next).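

In this assay, the step of a number 3.2 percentage points lower from compound 2 to compound 4 (within the scatter) and the step of a number 7 percentage points lower from compound 3 to compound 4 (within the scatter) leave 3,5-dimethyl-1H-pyrazol-1-yl on the carbonyl carbon not separated from the two acylamino-bearing groups, although it has 0 hydrogen-bond donors and fewer heavy atoms, so among these compounds that level does not depend on the acylamino arrangement. The step of a number 16.6 percentage points higher from compound 1 to compound 4 (beyond the scatter) shows that the difference from the benzylamino compound also survives without that arrangement. No measurement at hand explains this result.

Open, on these data alone, is whether the two methyl groups matter, which an unsubstituted 1H-pyrazol-1-yl group on the same carbonyl carbon would test, and whether a non-aromatic morpholin-4-yl group would hold the same level. With a single dose, the ranking of these compounds at other doses also remains open.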